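This account rests on a few compounds, and the source may have more. Where it says the series, first, only, none or still open, it means among the compounds named here.

Measured so far:
Compound 1 `CCCNC(=N)NC(=N)Nc1ccc(Cl)cc1` gives 2.63
Compound 2 `CCCCCCOC(=N)NC(=N)Nc1ccc(Cl)cc1` gives 4.32

In a physicochemical assay for lipophilicity, in phosphate buffer, measured as octanol-water partition, at pH 11.5 (on this read-out higher numbers stand for higher lipophilicity and lower numbers for lower lipophilicity), compound 2 stands highest of the two, and its gap to compound 1 lies beyond the scatter. Compound 3 `CCOC(=N)NC(=N)Nc1ccc(Cl)cc1` differs from compound 2 by hydrogen in place of butyl on a saturated chain carbon, two bonds along the chain from an oxygen on an unsaturated carbon, which also reads as hexyl to ethyl. Within the data shown here, no measured pair differs in one place only, so the size of this step remains a judgement. A fall beyond the scatter is expected, with an estimated a number 1.72 log units lower from compound 2 to compound 3 (beyond the scatter) in this assay. Compound 3 is expected at 2.6, within an estimated range of 2.1 to 3.1.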

Compound 3, partition coefficient: 2.32
For compound 3 the middle estimate is 0.28 log units above the measured one; measured number inside the range.
By their numbers in this assay, from the lowest: compound 3; then compound 1; then compound 2.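

In this assay, the hexyl to ethyl change gives the first measured size for this chain: a number 2.00 log units lower from compound 2 to compound 3 (beyond the scatter), a large step. Ethoxy in place of propylamino on a carbon with a double bond to nitrogen moves the number much less, a number 0.31 log units lower from compound 1 to compound 3 (beyond the scatter), a modest step. Nothing available gives a reason for either step. Going by these compounds, with only hexyl and ethyl read on this chain, it remains open whether the number changes evenly with chain length. On these data alone, it also remains open where a butoxy group would fall, or what a chain ending in a carboxylic acid would give.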